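The source may hold more compounds than are shown below. What is called first, only, known or untested is meant among the compounds shown, and "the series" means these compounds.

Working notes on the series. Compound 1 `CC(=O)Oc1ccc(/C=C/C(=O)OCCSc2nc(-c3ccc(S(C)(=O)=O)cc3)n(-c3ccc(F)cc3)n2)cc1OC(C)=O` gives 1050 nM in an assay on cells (strain Sprague-Dawley) for inhibition of Polyunsaturated fatty acid 5-lipoxygenase (Rattus norvegicus), with a stated time of 30 min; a lower number here means a stronger inhibitor, a higher number a weaker inhibitor. Compound 2 `CC(=O)Oc1ccc(/C=C/C(=O)OCCSc2nc(-c3ccc(S(C)(=O)=O)cc3)n(-c3ccccc3)n2)cc1OC(C)=O` gives 1210 nM in this assay; the change between them, (hydrogen in place of fluoro on an aromatic carbon), made a 1.2-fold higher number from compound 1 to compound 2 (0.06 log units; within the scatter). Compound 3 `CC(=O)Oc1ccc(/C=C/C(=O)OCCCSc2nc(-c3ccc(S(N)(=O)=O)cc3)n(-c3ccc(F)cc3)n2)cc1OC(C)=O` gives 1030 nM in this assay; the difference between the core of compound 3 and the core of compound 1 is not broken down here. Compound 4 `CC(=O)Oc1ccc(/C=C/C(=O)OCCCSc2nc(-c3ccc(S(N)(=O)=O)cc3)n(-c3ccccc3)n2)cc1OC(C)=O` is not yet measured; it differs from compound 3 by hydrogen in place of fluoro on an aromatic carbon, the same change as from compound 1 to compound 2, at a place described in the same words. Compound 4 is expected to sit near compound 3, with the step of a 1.2-fold higher number from compound 3 to compound 4 (0.07 log units; within the scatter) in this assay, because the earlier step of a 1.2-fold higher number from compound 1 to compound 2 (0.06 log units; within the scatter) lay within the scatter. Compound 4 is therefore estimated at 1200 nM, between 600 nM and 2400 nM.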

Compound 4, half-maximal inhibitory concentration: 1070 nM
For compound 4 the middle estimate is 1.1-fold (0.05 log units) above the measured one; the range from low to high includes it.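

In this assay the change from 4-fluorophenyl to phenyl gives a 1.0-fold higher number from compound 3 to compound 4 (0.02 log units; within the scatter) on the core of compound 3, so on these two cores the change carries over with no readable shift: the same change on two cores in this assay, a 1.2-fold higher number (0.06 log units; within the scatter) from compound 1 to compound 2 and a 1.0-fold higher number (0.02 log units; within the scatter) from compound 3 to compound 4, 1.1-fold (0.05 log units) apart, within the scatter of two such steps

This shows only that the fluoro can be replaced by hydrogen on both cores without leaving the scatter. It does not show that the change is silent on any other core or in any other test, and two steps this small cannot separate a slight real effect from noise.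

Still open, from the compounds shown here alone, is whether a larger group at the same place, such as methoxy or an amine, would move the number. Also open, going by these compounds, is whether a longer chain on either core would do so.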